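The compounds below may be only part of what the source reports. "The series", "measured", "known", "first", "only" and "open" are said of these compounds alone.

Compound 1 `CCC(=O)Nc1c(C(O)(C(F)(F)F)C(F)(F)F)ccc2ccccc12` gives 15 nM in an assay on LtK cells with ATP-sensitive inward rectifier potassium channel 11 (Homo sapiens) as the target; on this read-out lower numbers stand for an effect already at smaller amounts and higher numbers for an effect only at larger amounts of compound. Compound 2 `CC(C)C(=O)Nc1c(C(O)(C(F)(F)F)C(F)(F)F)ccc2ccccc12` gives 6630 nM, and compound 3 `CCC(C)C(=O)Nc1c(C(O)(C(F)(F)F)C(F)(F)F)ccc2ccccc12` gives 177000 nM, the highest number of the three. The measured steps all run the same way: a 440-fold higher number from compound 1 to compound 2 (2.65 log units; beyond the scatter), a 12000-fold higher number from compound 1 to compound 3 (4.07 log units; beyond the scatter) and a 27-fold higher number from compound 2 to compound 3 (1.43 log units; beyond the scatter), so every addition along the saturated chain of the amide raised the number. Compound 4 `N#Cc1cccc(C(=O)Nc2c(C(O)(C(F)(F)F)C(F)(F)F)ccc3ccccc23)c1` differs from compound 3 by 3-cyanophenyl in place of sec-butyl on a carbonyl carbon. Going by the values given here, no measured step covers an aromatic group on the carbonyl carbon, so the alkyl steps give no direct guide; they show only that compound 3 sits far above compound 1. For compound 4 a lower number is expected, an 8.9-fold lower number from compound 3 to compound 4 (0.95 log units; beyond the scatter), with an estimate of 20000 nM and a range from 2000 nM to 200000 nM.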

Compound 4, half-maximal effective concentration: 12 nM
For compound 4 the middle estimate is 1700-fold (3.22 log units) above the measured one; the measured number lies below the stated range.
By their numbers in this assay, from the lowest: compounds 4 and 1 (each within the scatter of the next); then compound 2; then compound 3.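

On the carbonyl carbon, the alkyl steps had only raised the number as the chain grew, but 3-cyanophenyl, with more heavy atoms than any of those groups, goes against that pattern (a 15000-fold lower number from compound 3 to compound 4 (4.17 log units; beyond the scatter); a 550-fold lower number from compound 2 to compound 4 (2.74 log units; beyond the scatter)). Against ethyl, the same replacement gives no readable difference (a 1.3-fold lower number from compound 1 to compound 4 (0.10 log units; within the scatter)). No measurement shown explains this reversal.

Going by these compounds, whether the result depends on the aromatic ring or on the nitrile remains open. A plain phenyl or a 3-aminophenyl on the carbonyl carbon would separate the two.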